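The source may report more compounds than this note shows. Statements on the series, on what has been measured and on what is new or still open speak of the compounds shown alone.

Measured compounds in an assay on isolated protein for inhibition of RAC-alpha serine/threonine-protein kinase (Homo sapiens), read by fluorescence, with a stated time of 30 min, tested at 10 uM; a lower number here means less inhibition, a higher number more inhibition at the concentration tested (going by the name of the read-out):

compound 1 `COc1cccc(C(=O)Nc2cc(Sc3ncn[nH]3)c(O)c3ccccc23)c1`, 19.4%
compound 2 `Cc1cccc(C(=O)Nc2cc(Sc3ncn[nH]3)c(O)c3ccccc23)c1`, 20.2%
compound 3 `COc1ccc(/C=C/C(=O)Nc2cc(Sc3ncn[nH]3)c(O)c3ccccc23)cc1OC`, 31.7%

Compound 3 stands highest of the three numbers; its nearest neighbour is compound 2, which sits beyond the scatter below it, and compound 1 sits further below, also beyond the scatter. Compound 3 is therefore the only one of the three whose inhibition clearly separates from the others.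

Compound 4 `O=C(/C=C/c1ccc(Cl)cc1)Nc1cc(Sc2ncn[nH]2)c(O)c2ccccc12` has not been measured. It differs from compound 3 as follows: 4-chlorophenyl in place of 3,4-dimethoxyphenyl on a double-bonded chain carbon bound to a double-bonded chain carbon

Within the data shown here, only one measured step bears on this change, and only loosely: a number 0.8 percentage points higher from compound 1 to compound 2 (within the scatter), where a methyl replaced a methoxy on an aromatic carbon of the benzamide part of the shared core and the number stayed within the scatter. That step concerns a different ring and a single substituent, whereas the present change removes both methoxy groups of the 3,4-dimethoxyphenyl and introduces a chlorine at a different place. Among the measured compounds shown here, no measured pair shows what the loss of two methoxy groups does on this chain. The expectation for compound 4 in this assay is a step of a number 4.7 percentage points lower from compound 3 to compound 4 (within the scatter), downward but not expected to exceed the scatter, resting on the small size of the step from compound 1 to compound 2. Compound 4 is estimated at 27%, with a range from 14% to 40%.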

Compound 4, a percentage reported as inhibition, at one concentration (the size of the read-out at that concentration, not a potency): 31.8%
Estimate against measurement, compound 4: 4.8 percentage points below; low and high end bracket the measured number.
By their numbers in this assay, from the lowest: compounds 1 and 2 (each within the scatter of the next); then compounds 3 and 4 (each within the scatter of the next).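

In this assay, the step on the double-bonded chain carbon is a number 0.1 percentage points higher from compound 3 to compound 4 (within the scatter), so this position accepts 4-chlorophenyl in place of 3,4-dimethoxyphenyl without a change beyond the scatter, and the methoxy groups are not required for the number seen with compound 3. On the carbonyl carbon, 2-(4-chlorophenyl)ethenyl in place of 3-methylphenyl gives a number 11.6 percentage points higher from compound 2 to compound 4 (beyond the scatter), and in place of 3-methoxyphenyl it gives a number 12.4 percentage points higher from compound 1 to compound 4 (beyond the scatter); both steps are modest, and each replaces the chain and the aromatic group together, so neither can be assigned to the chain alone. Nothing at hand gives a reason for the flat step on the chain or for the two modest steps on the carbonyl carbon.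

Still open, going by these compounds, is whether an unsubstituted phenyl, an amine or a carboxylic acid on the aromatic ring, or a saturated ethyl chain in place of the double-bonded chain would hold, raise or lower the number in this assay. On these data alone, these read-outs also stand at a single concentration, so how the compounds compare in potency remains unknown.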